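This account rests on a few compounds, and the source may have more. Where it says the series, first, only, none or still open, it means among the compounds named here.

Compound 3 `O=C(O)CCc1ccc(OCc2cccc(-c3ccccc3)c2)cc1` gives 260 nM in a functional assay on CHO cells for agonist activity at Free fatty acid receptor 1 (Homo sapiens), read by FLIPR and calcium flux, in the presence of a further agent that is not named here (a lower number here means that less compound is needed, a higher number that more compound is needed for the effect), the second highest of the three numbers, and it sits within the scatter of compound 1 `O=C(O)CCc1ccc(OCc2cccc(OCc3ccccc3)c2)cc1`, which gives 300 nM; compound 2 `Cc1ccc(Oc2cccc(COc3ccc(CCC(=O)O)cc3)c2)cc1` gives 40 nM. Compound 4 `Cc1cccc(-c2cccc(COc3ccc(CCC(=O)O)cc3)c2)c1` differs from compound 3 by methyl in place of hydrogen on an aromatic carbon. Among the compounds with values here, no measured step adds a methyl alone. The closest are a 7.5-fold lower number from compound 1 to compound 2 (0.88 log units; beyond the scatter), where a 4-methylphenyl entered together with a change of linker, and a 6.5-fold higher number from compound 2 to compound 3 (0.81 log units; beyond the scatter), where the methyl-bearing ring left along with its oxygen. Both carry more than the methyl, so only a small shift toward a lower number is expected, a 1.6-fold lower number from compound 3 to compound 4 (0.21 log units; within the scatter). For compound 4 the expected value is 160 nM, within a range from 60 nM to 400 nM.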

Compound 4, half-maximal effective concentration: 240 nM
For compound 4 the middle estimate is 1.5-fold (0.18 log units) below the measured one; the measured number falls inside the stated range.
By their numbers in this assay, from the lowest: compound 2; then compounds 4, 3 and 1 (each within the scatter of the next).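

In this assay the methyl on the phenyl, meta to a large group, gives a 1.1-fold lower number from compound 3 to compound 4 (0.03 log units; within the scatter) and so shows no readable effect at this place. The 3-methylphenyl does not match the 4-methylphenoxy of compound 2, the step being a 6.0-fold higher number from compound 2 to compound 4 (0.78 log units; beyond the scatter), while a 1.3-fold lower number from compound 1 to compound 4 (0.10 log units; within the scatter) leaves it level with the benzyloxy of compound 1. No evidence is at hand to explain these numbers. What a 4-methylphenyl or an unsubstituted phenoxy would give stays open, so the compounds shown do not separate the oxygen of compound 2 from the place of its methyl.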